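The source may hold more compounds than are shown below. What is called first, only, known or untested is meant among the compounds shown, and "the series" means these compounds.

Compound 1 `C=CC(=O)Nc1cccc(Nc2nc(N/N=C(\C)c3ccc(OC)cc3)ncc2Cl)c1` gives 4560 nM in an ADME assay on HT-29 cells (Homo sapiens) for inhibition, read by MTT assay, with a stated time of 72 h; on this read-out lower numbers stand for stronger inhibition and higher numbers for weaker inhibition. Compound 2 `C=CC(=O)Nc1cccc(Nc2nc(N/N=C(\C)c3cccc(OC)c3)ncc2Cl)c1` gives 8990 nM in this assay, and the change between them is 3-methoxyphenyl in place of 4-methoxyphenyl on a carbon with a double bond to nitrogen, with the step of a 2.0-fold higher number from compound 1 to compound 2 (0.29 log units; within the scatter). Compound 3 `COc1ccc(/C(C)=N/Nc2ncc(Cl)c(Nc3cccc(NC(=O)/C=C/CN(C)C)c3)n2)cc1` gives 6830 nM in this assay; its core differs from that of compound 1 by 3-(dimethylamino)prop-1-en-1-yl in place of vinyl on a carbonyl carbon, a step of a 1.5-fold higher number from compound 1 to compound 3 (0.18 log units; within the scatter). Compound 4 `COc1cccc(/C(C)=N/Nc2ncc(Cl)c(Nc3cccc(NC(=O)/C=C/CN(C)C)c3)n2)c1`, not yet measured, differs from compound 3 by 3-methoxyphenyl in place of 4-methoxyphenyl on a carbon with a double bond to nitrogen, which is the same change as that from compound 1 to compound 2, at the same place. Because the earlier step was a 2.0-fold higher number from compound 1 to compound 2 (0.29 log units; within the scatter), a step of similar size is expected here, namely a 1.8-fold higher number from compound 3 to compound 4 (0.24 log units; within the scatter). The value of compound 4 in this assay is therefore estimated at 12000 nM, most likely between 6000 nM and 25000 nM.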

Compound 4, half-maximal inhibitory concentration: 3870 nM
Estimate against measurement, compound 4: 3.1-fold (0.49 log units) above; measured number below the stated range.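

On the core carrying 3-(dimethylamino)prop-1-en-1-yl, 3-methoxyphenyl in place of 4-methoxyphenyl gives a 1.8-fold lower number from compound 3 to compound 4 (0.25 log units; within the scatter), which runs the opposite way to the earlier step: the same change on two cores in this assay, a 2.0-fold higher number (0.29 log units; within the scatter) from compound 1 to compound 2 and a 1.8-fold lower number (0.25 log units; within the scatter) from compound 3 to compound 4, 3.5-fold (0.54 log units) apart, beyond the scatter of two such steps

Likewise, 3-(dimethylamino)prop-1-en-1-yl in place of vinyl gives a 2.3-fold lower number from compound 2 to compound 4 (0.37 log units; beyond the scatter), so its step also shifts with the core: the same change on two cores in this assay, a 1.5-fold higher number (0.18 log units; within the scatter) from compound 1 to compound 3 and a 2.3-fold lower number (0.37 log units; beyond the scatter) from compound 2 to compound 4, 3.5-fold (0.54 log units) apart, beyond the scatter of two such steps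

In these four compounds, then, the size of neither step transfers from one core to the other, but this does not show why, nor how a further core would respond.

The compounds shown leave open whether a diethylamino group in place of dimethylamino, or an ethoxy group in place of methoxy, would show the same dependence on the core.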